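Blood half-life across the ester variants of the series

The source may hold more compounds than are shown below. What is called first, only, known or untested is meant among the compounds shown, and "the series" means these compounds.

Measured so far:
compound 1 `CC(C)(C)C(=O)OCO[P@@]1(=O)OCC(C)(C)[C@H](C(=O)NCCC(=O)O)O1` — an ADME assay on blood (Homo sapiens) for pharmacokinetics; a lower number here means that the compound disappears faster, a higher number that the compound lasts longer: > 1 h
compound 2 `CC(C)(C)C(=O)OCO[P@@]1(=O)OCC(C)(C)[C@H](C(=O)NCCC(=O)OCCS(C)(=O)=O)O1` — this assay : < 0.16 h

The value of compound 1 is a limit of the assay (the limit of > 1 h in this assay, at which 1 of the 2 values shown sits). The value of compound 2 is also a limit (the limit of < 0.16 h in this assay, at which 1 of the 2 values shown sits). Both numbers shown are limits, and compound 2 sits at the lower one. Going by the values given here, the only measured step is an at least 6.2-fold lower number from compound 1 to compound 2 (0.79 log units; beyond the scatter). Compound 3 `CC(C)(C)C(=O)OCO[P@@]1(=O)OCC(C)(C)[C@H](C(=O)NCCC(=O)OCCc2ccccn2)O1` differs from compound 2 by pyridin-2-yl in place of methylsulfonyl on a saturated chain carbon, two bonds along the chain from an oxygen next to a carbonyl group. Among the compounds with values here, no measured step covers this change; compound 3 keeps the substituted oxygen next to the carbonyl group that compound 2 carries, so no step beyond the scatter is expected, that is a step that the limit leaves unreadable from compound 2 to compound 3. For compound 3 the expected half-life is 0.12 h, range 0.04 h to 0.45 h, most likely again reported as a limit.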

Compound 3, half-life: < 0.16 h
Compound 3: only a limit was reported (the forecaster's own chance of this, stated with the estimate: 65%); the middle value does not contradict the limit.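

Putting 2-(pyridin-2-yl)ethyl in place of hydrogen on this oxygen gives an at least 6.2-fold lower number from compound 1 to compound 3 (0.79 log units; beyond the scatter) in this assay, so the short half-life is not confined to the 2-(methylsulfonyl)ethyl ester. Compound 3 gives < 0.16 h, which is a limit. The step from compound 2 to compound 3 cannot be read, because both compounds sit at the same limit: the limit of < 0.16 h in this assay, at which 2 of the 3 values shown sit.

From the compounds shown here alone, the true half-lives of these two esters remain open. So does whether a 2-(dimethylamino)ethyl ester or a simple methyl ester would also fall at this limit.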